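The source may report more compounds than this note shows. Statements on the series, on what has been measured and on what is new or still open speak of the compounds shown alone.

Measured so far: compound 1 `COc1cc(-c2cc(/C=C/C(=O)c3ccc(N)cc3)[nH]n2)cc(OC)c1OC` gives 6530 nM in a functional assay on HCC 2998 cells (Homo sapiens) for inhibition, read by sulforhodamine B assay, with a stated time of 48 h; a lower number here means that less compound is tolerated, a higher number that more compound is tolerated. Compound 2 `COc1cc(-c2cc(/C=C/C(=O)c3ccc(Cl)c(Cl)c3)[nH]n2)cc(OC)c1OC` gives only a limit in this assay, > 100000 nM. Compound 3 `COc1ccc(C(=O)/C=C/c2cc(-c3cc(OC)c(OC)c(OC)c3)n[nH]2)cc1` gives 6480 nM in this assay.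

Compound 3 holds the lowest of the two numbers given, with compound 1 within the scatter of it, while the remaining value is a limit. Compound 4 `COc1cc(-c2cc(/C=C/C(=O)c3ccc(F)c(F)c3)[nH]n2)cc(OC)c1OC` differs from compound 3 by 3,4-difluorophenyl in place of 4-methoxyphenyl on a carbonyl carbon. The step that bears most directly is an at least 15-fold lower number from compound 2 to compound 3 (1.18 log units; beyond the scatter), and an at least 15-fold higher number from compound 1 to compound 2 (1.18 log units; beyond the scatter) points the same way, both involving a 3,4-dihalogenated phenyl on that carbonyl carbon. A large rise is therefore expected, a 6.9-fold higher number from compound 3 to compound 4 (0.84 log units; beyond the scatter), with a real chance that only the limit of > 100000 nM in this assay, at which 1 of the 3 values shown sits, is reported. Compound 4 is estimated at 45000 nM, between 10000 nM and 200000 nM.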

Compound 4, concentration lethal to 50% of the cells: > 100000 nM
Compound 4 was reported as a limit; the forecaster's own chance of this, stated with the estimate: 40%; middle value at least 2.2-fold (0.34 log units) away from the limit.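

In this assay, 3,4-difluorophenyl on the carbonyl carbon brings an at least 15-fold higher number from compound 3 to compound 4 (1.18 log units; beyond the scatter), and likewise an at least 15-fold higher number from compound 1 to compound 4 (1.18 log units; beyond the scatter). The jump seen with 3,4-dichlorophenyl is therefore not tied to chlorine, and among these compounds both dihalogenated phenyl groups end at a limit, while 4-aminophenyl and 4-methoxyphenyl give real numbers: the limit of > 100000 nM in this assay, at which 2 of the 4 values shown sit. The step from compound 2 to compound 4 cannot be read, as both values are limits.

Going by these compounds, it remains open whether 4-fluorophenyl or 4-hydroxyphenyl on that carbonyl carbon would give a number or a limit. The two dihalogenated groups also cannot be ranked against each other.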